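From acetyl to trifluoromethyl: cytotoxicity notes

This account rests on a few compounds, and the source may have more. Where it says the series, first, only, none or still open, it means among the compounds named here.

Measured so far in an ADME assay on MT2 cells (Homo sapiens) for cytotoxicity, read by XTT assay, with a stated time of 4 days; a higher number here means that more compound is tolerated, a lower number that less compound is tolerated:
compound 1 `Cc1ccc(NC(=O)C(=O)NC(c2nc(C)c(CO)s2)C2CCCCN2)c(F)c1` gives > 109000 nM as a limit
compound 2 `CC(=O)c1ccc(NC(=O)C(=O)NC(c2nc(C)c(CO)s2)C2CCCCN2)cc1` gives > 107000 nM as a limit

Compound 2 stands at > 107000 nM in this assay as a limit and not a number. Among the compounds with values here, the only other value shown is also a limit. Compound 3 `Cc1nc(C(NC(=O)C(=O)Nc2ccc(C(F)(F)F)cc2)C2CCCCN2)sc1CO` carries trifluoromethyl in place of acetyl on an aromatic carbon, para to a large group, with the difference counted as trifluoromethyl in place of acetyl on an aromatic carbon here. Within the data shown here, the one measured change is a step that the two limits leave unreadable from compound 1 to compound 2 and it sits on an amide-type nitrogen, so it offers no size to carry over. No step beyond the scatter is therefore expected in this assay and no direction can be given. The expected outcome is an at least 1.1-fold lower number from compound 2 to compound 3 (0.07 log units; that floor lies within the scatter) as an estimate only. For compound 3 the estimated value is 90000 nM with an expected range from 35000 nM to 130000 nM and another limit is quite possible.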

Compound 3, half-maximal cytotoxic concentration: > 75500 nM
Compound 3 was reported as a limit; the forecaster's own chance of this, stated with the estimate: 60%; the middle value lies beyond the limit too.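

In this assay, within the data shown here, compound 1, compound 2 and compound 3 are all reported as limits and not numbers, and no step among them can be read. The compounds shown leave open where each half-maximal cytotoxic concentration lies, and whether trifluoromethyl in place of acetyl shifts it at all.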